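The source may hold more compounds than are shown below. What is called first, only, known or untested is meant among the compounds shown, and "the series" means these compounds.

Of the compounds shown here, three built on one shared core have been measured in a functional assay on UACC-257 cells (Homo sapiens) for antiproliferative activity, with a stated time of 48 h; a lower number here means a stronger inhibitor of growth, a higher number a weaker inhibitor of growth. Compound 1 `Cc1cc(O)c(C2=NN(c3ccc(S(N)(=O)=O)cc3)C(c3ccccc3O)C2)cc1Cl` gives 6920 nM, compound 2 `Cc1cc(O)c(C2=NN(c3ccc(S(N)(=O)=O)cc3)C(c3ccccc3Cl)C2)cc1Cl` gives 11800 nM, and compound 3 `Cc1cc(O)c(C2=NN(c3ccc(S(N)(=O)=O)cc3)C(/C=C/c3ccccc3)C2)cc1Cl` gives 14500 nM, the highest of the three numbers. The two steps reaching compound 3, a 2.1-fold higher number from compound 1 to compound 3 (0.32 log units; beyond the scatter) and a 1.2-fold higher number from compound 2 to compound 3 (0.09 log units; within the scatter), both alter the group on the saturated ring carbon and point in the same direction. Compound 4 `COc1ccc(C2CC(c3cc(Cl)c(C)cc3O)=NN2c2ccc(S(N)(=O)=O)cc2)cc1OC` changes that same position: 3,4-dimethoxyphenyl in place of 2-phenylethenyl on a saturated ring carbon. With that change, compound 4 again carries an aromatic ring at the carbon where compounds 1 and 2 carry theirs. A modest lowering is therefore expected for compound 4, a 1.5-fold lower number from compound 3 to compound 4 (0.16 log units; within the scatter), possibly no larger than the scatter. The estimate for compound 4 in this assay is 10000 nM, with a range from 5000 nM to 20000 nM.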

Compound 4, concentration for 50% growth inhibition: 4220 nM
Estimate against measurement, compound 4: 2.4-fold (0.37 log units) above; the measured number lies below the stated range.
By their numbers in this assay, from the lowest: compounds 4, 1, 2 and 3 (each within the scatter of the next, the first and the last beyond it).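

At the saturated ring carbon, 3,4-dimethoxyphenyl gives the clearest lowering seen so far in this assay when it replaces 2-phenylethenyl (a 3.4-fold lower number from compound 3 to compound 4 (0.54 log units; beyond the scatter)) or 2-chlorophenyl (a 2.8-fold lower number from compound 2 to compound 4 (0.45 log units; beyond the scatter)). Against 2-hydroxyphenyl, the change stays within the scatter (a 1.6-fold lower number from compound 1 to compound 4 (0.21 log units; within the scatter)), so compound 4 and compound 1 cannot be ordered. This position therefore accepts 3,4-dimethoxyphenyl as well as any other group shown here. On these data alone, whether a single methoxy group, an amine or a carboxylic acid on this ring would serve equally well remains open. No measured property on hand accounts for these differences.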